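A few compounds are considered here, and "the series" means these few. Any claim that something is new, unique, unknown or untested is made for them only; others in the source may bear on it.

Compound 2 `COc1ccc(CN2CCc3nc(-c4ccccn4)nc(N4CCC(C(N)=O)CC4)c3C2)cc1` holds the highest of the two numbers in an assay on FRT cells with Cystic fibrosis transmembrane conductance regulator variant F508del (Homo sapiens) as the target, read by fluorescence, with a stated time of 25 min (a higher number here means a larger maximal response, a lower number a smaller maximal response), where compound 2 gives 86.6%, and compound 1 `NC(=O)C1CCN(c2nc(-c3ccccn3)nc3c2CN(Cc2ccccc2)CC3)CC1` gives 56.6%. For the measured compounds named here, the only measured step, a number 30 percentage points higher from compound 1 to compound 2 (beyond the scatter), concerns a change elsewhere on the molecule and does not bear on the present exchange. Compound 3 `CCN(C(C)=O)C1CCN(c2nc(-c3ccccn3)nc3c2CN(Cc2ccc(OC)cc2)CC3)C1` differs from compound 2 by 3-(acetyl(ethyl)amino)pyrrolidin-1-yl in place of 4-carbamoylpiperidin-1-yl on an aromatic carbon. Going by the values given here, no measured step covers such an exchange, so the expectation rests on little. The step of a number 21.6 percentage points lower from compound 2 to compound 3 (beyond the scatter) is expected to be downward but uncertain. For compound 3 the estimate in this assay is 65%, within a range from 35% to 95%.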

Compound 3, largest response reached (Emax), in percent of the reference or control that the assay uses: 36.9%
Compound 3: middle estimate off by 28.1 percentage points, on the high side, within the range that was stated.
By their numbers in this assay, from the lowest: compound 3; then compound 1; then compound 2.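

Putting 3-(acetyl(ethyl)amino)pyrrolidin-1-yl in place of 4-carbamoylpiperidin-1-yl brings, in this assay, a number 49.7 percentage points lower from compound 2 to compound 3 (beyond the scatter), so this position, which the earlier step left untouched, is not indifferent to the group it carries. The five-membered ring, the acetyl(ethyl)amino group and the loss of the hydrogen-bond donor arrive together, and this single step cannot separate them. Nothing available explains the drop.

Open, as far as these compounds go, is which of these changes matters: a pyrrolidine carrying carbamoyl, or a piperidine carrying acetyl(ethyl)amino, could separate ring from substituent. From the compounds shown here alone, how a carboxylic acid on the piperidine would fare also remains open.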